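Replacing the pyridinyl group on the amine nitrogen with 4-fluorophenyl

The source may report more compounds than this note shows. Statements on the series, on what has been measured and on what is new or still open speak of the compounds shown alone.

Measured compounds in an assay on HEK293 cells for inhibition of sodium-dependent dopamine transporter (Homo sapiens); on this read-out lower numbers stand for lower potency and higher numbers for higher potency (the scale is a negative logarithm):
- compound 1, `c1ccc(CCCN2CCN(CCCN(Cc3ccccc3)c3ccccn3)CC2)cc1`: 5.93; 7.82 (2 entries)
- compound 2, `COc1ccc(CN(CCCN2CCN(CCCc3ccccc3)CC2)c2ccccn2)cc1`: 7.08
- compound 3, `Fc1ccc(CN(CCCN2CCN(CCCc3ccccc3)CC2)c2ccccn2)cc1`: 6.91

Compound 1 appears twice in this assay, and its two entries are far apart, as the several entries of compound 1 in this assay, 5.93; 7.82 (2 entries) shows, so it gives no single number. Among the remaining two, compound 3 has the lower number, with compound 2 nearest; the step of a number 0.17 log units lower from compound 2 to compound 3 (within the scatter) separates them, which is no more than the usual scatter. Compound 3 therefore stands on a par with compound 2, and nothing in this series is the strongest or the weakest.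

Compound 4, `Fc1ccc(CN(CCCN2CCN(CCCc3ccccc3)CC2)c2ccc(F)cc2)cc1`, differs from compound 3 in one place: 4-fluorophenyl in place of pyridin-2-yl on an amine nitrogen. Going by the values given here, none of the measured steps touches this position. Among the compounds with values here, the only measured step, from compound 2 to compound 3, concerns the substituent on the benzyl ring, not the group on the amine nitrogen, so it does not bear on the change at hand. Within the data shown here, with no direct precedent, compound 4 is expected to stay close to compound 3, with a step of a number 0.21 log units lower from compound 3 to compound 4 (within the scatter) that need not exceed the scatter. For compound 4 the estimate in this assay is 6.7, within a range from 6 to 7.4.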

Compound 4, logarithm of the reciprocal of the active concentration, log(1/C): 6.82
The estimate for compound 4 lay 0.12 log units below the measured number; the measured number falls inside the stated range.
By their numbers in this assay, from the lowest: compounds 4, 3 and 2 (each within the scatter of the next).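

In this assay, the first change shown at this position, 4-fluorophenyl in place of pyridin-2-yl on the amine nitrogen, gives a number 0.09 log units lower from compound 3 to compound 4 (within the scatter). Going by these compounds alone, until now, the only step read had concerned the substituent on the benzyl ring, so this is the first sign that the group on the amine nitrogen can also be exchanged without a step beyond the scatter, even though the group that leaves has 1 hydrogen-bond acceptor and a ring hetero atom, while the group that enters has 0 hydrogen-bond acceptors and a ring of carbon only. Nothing shown here bears on why the two numbers stay within the scatter of each other.

Within the data shown here, this exchange is seen only with the fluoro substituent on the benzyl ring, so whether it would behave the same way with the methoxy substituent of compound 2 remains open. Going by these compounds, it also remains open what a group of a different kind on the same amine nitrogen, such as a methyl group or a saturated cyclohexyl ring, would do to the number.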